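Ethyl Ester Versus Free Acid on a Cytotoxicity Read-out

This account rests on a few compounds, and the source may have more. Where it says the series, first, only, none or still open, it means among the compounds named here.

Of the compounds shown here, three have been measured so far in a functional assay on EA.hy 926 cells (Homo sapiens) for cytotoxicity, read by MTT assay, with stated times of 24 h and 12 h, tested at 12.5 uM; a higher number here means a stronger effect of the compound at the concentration tested, a lower number a weaker effect. Compound 1 `Cc1nc(C)c(C(=O)Oc2ccc(/C=C/C(=O)O)cc2)nc1C` gives 34.2%. Compound 2 `Cc1nc(C)c(C(=O)Oc2cccc(/C=C/C(=O)O)c2)nc1C` gives 61.6%. Compound 3 `CCOC(=O)/C=C/c1ccc(OC(=O)c2nc(C)c(C)nc2C)cc1` gives 42.7%. Compound 1 and compound 2 are built from the same atoms joined differently; the difference between their cores is not broken down here. Among the three, compound 2 stands highest, and its distance to each of the other two lies beyond the usual scatter of this kind of measurement.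

Compound 1 and compound 3 differ in one place only, by ethyl in place of hydrogen on an oxygen next to a carbonyl group. This change produced a number 8.5 percentage points higher from compound 1 to compound 3 (within the scatter), a step that stays within the scatter, so on this pair the ester and the free acid behave alike within the precision of this assay.

Compound 4 `CCOC(=O)/C=C/c1cccc(OC(=O)c2nc(C)c(C)nc2C)c1` has not yet been measured. It relates to compound 2 exactly as compound 3 relates to compound 1: the change is ethyl in place of hydrogen on an oxygen next to a carbonyl group, at the same place on the core of compound 2. Among the measured compounds shown here, the step from compound 2 to compound 4 is therefore expected to be of similar size to the earlier one, which rests on the single measured example a number 8.5 percentage points higher from compound 1 to compound 3 (within the scatter), and is estimated as a number 4.4 percentage points higher from compound 2 to compound 4 (within the scatter). In this assay compound 4 is expected to give 66%, estimated between 50% and 80%, pending the measurement.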

Compound 4, a percentage reported as activity, at one concentration (the size of the read-out at that concentration, not a potency): 27.9%
The estimate for compound 4 lay 38.1 percentage points above the measured number; measured number below the stated range.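

On the core of compound 2, turning the carboxy group into an ethoxycarbonyl group, with ethyl in place of hydrogen on the oxygen, gave a number 33.7 percentage points lower from compound 2 to compound 4 (beyond the scatter) in this assay. Among the compounds shown here, this shows that the change cannot simply be carried from one core to another, since the size and even the direction of its effect here depend on the core that bears it; it does not show what in the two cores causes this, and with only one acid and ester pair on each core it gives no rule for any further core. Set side by side, the two steps do not agree: the same change on two cores in this assay, a number 8.5 percentage points higher (within the scatter) from compound 1 to compound 3 and a number 33.7 percentage points lower (beyond the scatter) from compound 2 to compound 4, 42.2 percentage points apart, beyond the scatter of two such steps.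

The compounds shown leave open whether an ester with a different chain in place of ethyl, such as methyl or butyl, would split between the two cores in the same way. They also leave open how an amide in place of the ethoxycarbonyl group would behave on either core, and so whether the split belongs to the ethyl ester alone or extends to other replacements of the carboxy group.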